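The source may hold more compounds than are shown below. What is called first, only, known or untested is meant among the compounds shown, and "the series" means these compounds.

Compound 1 `CCOC(=O)c1ccc(-c2nn(C)c3ccccc23)cc1` in a functional assay on cells (Platelet, Homo sapiens) for inhibition; a lower number here means a stronger inhibitor, a higher number a weaker inhibitor: 270 nM.
Compound 2 `CCOC(=O)c1ccc(-c2nn(Cc3ccc(F)cc3)c3ccccc23)cc1` in this assay: 190 nM.

Compound 2 gives 190 nM; compound 1 gives 270 nM, and the two values lie within the scatter of each other, so neither can be called the stronger inhibitor. Compound 3 `CCOC(=O)c1ccc(-c2nn(Cc3ccc(OC)cc3)c3ccccc23)cc1` differs from compound 2 by methoxy in place of fluoro on an aromatic carbon. For the measured compounds named here, the only measured step, a 1.4-fold lower number from compound 1 to compound 2 (0.15 log units; within the scatter), touches the same part of the molecule but adds the whole 4-fluorobenzyl group rather than exchanging one substituent on it, and it stayed within the scatter. A change no larger than that is expected here, so compound 3 is estimated at 190 nM (range 80 nM to 450 nM), a step of no change at the digits printed from compound 2 to compound 3 (within the scatter) that is expected to remain within the scatter.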

Compound 3, half-maximal inhibitory concentration: 620 nM
For compound 3 the middle estimate is 3.3-fold (0.51 log units) below the measured one; the measured number lies above the stated range.
By their numbers in this assay, from the lowest: compounds 2 and 1 (each within the scatter of the next); then compound 3.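

The para position of this group is not neutral: in this assay, methoxy in place of fluoro gives a 3.3-fold higher number from compound 2 to compound 3 (0.51 log units; beyond the scatter), so a small exchange on the aromatic ring moves the number beyond the scatter. Adding the whole 4-methoxybenzyl group in place of a hydrogen on the chain carbon gives a 2.3-fold higher number from compound 1 to compound 3 (0.36 log units; beyond the scatter), whereas adding the 4-fluorobenzyl group stayed within the scatter. Nothing available explains this difference. On these data alone, how an amine or a carboxylic acid at this same ring position would compare remains open.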